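A few compounds are considered here, and "the series" means these few. Any claim that something is new, unique, unknown or untested is made for them only; others in the source may bear on it.

Measured compounds:
- compound 1, `Cc1cc(Nc2nc(Nc3ccc(C(=O)NC4CC(C)(C)N([O])C(C)(C)C4)cc3)ncc2[N+](=O)[O-])no1`: 7360 nM
- compound 2, `CCOC(=O)c1csc(Nc2nc(Nc3ccc(C(=O)NC4CC(C)(C)N([O])C(C)(C)C4)cc3)ncc2[N+](=O)[O-])n1`: 3790 nM

Both numbers come from a functional assay on HeLa cells (Homo sapiens) for antiproliferative activity, read by MTT assay, with a stated time of 48 h; a lower number here means a stronger inhibitor, a higher number a weaker inhibitor. Compound 1 holds the highest number of the two, and its nearest neighbour is compound 2, which differs only by a 1.9-fold lower number from compound 1 to compound 2 (0.29 log units; within the scatter), a gap that stays within the usual scatter.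

Compound 3, `Cc1cc(Nc2nc(Nc3ccc(C(=O)NC4CC(C)(C)N([O])C(C)(C)C4)cc3)ncc2F)no1`, has not yet been measured. It differs from compound 1 by fluoro in place of nitro on an aromatic carbon, a change on the core ring, para to a large group and two atoms from the ring nitrogen. Going by the values given here, the only measured step, the one from compound 1 to compound 2, alters a different part of the molecule and was itself within the scatter, so it offers no direct guide to swapping nitro for fluoro. Among the compounds with values here, with no comparable step available, the expectation is uncertain and set near the present number, with a wide range.

For compound 3 the estimate in this assay is 10000 nM, between 2500 nM and 40000 nM, meaning an expected step of a 1.4-fold higher number from compound 1 to compound 3 (0.13 log units; within the scatter).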

Compound 3, half-maximal inhibitory concentration: 5680 nM
Compound 3: middle estimate off by 1.8-fold (0.25 log units), on the high side; measured number inside the range.
By their numbers in this assay, from the lowest: compounds 2, 3 and 1 (each within the scatter of the next).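

In this assay, fluoro in place of nitro on this aromatic carbon, ortho to a (5-methyl-1,2-oxazol-3-yl)amino group and para to a large group, gives a 1.3-fold lower number from compound 1 to compound 3 (0.11 log units; within the scatter). This position therefore accepts a swap from nitro, with 3 heavy atoms and 2 hydrogen-bond acceptors, to fluoro, with 1 heavy atom and no hydrogen-bond acceptors, while the two numbers remain within the scatter of each other. No measurement here offers an explanation for this result.

Still open, from the compounds shown here alone, is whether an amine, a nitrile or a carboxylic acid on the same carbon would also give a number within the scatter of compound 1. Going by these compounds, it is also open whether fluoro in place of nitro would give a similar step with the 4-(ethoxycarbonyl)-1,3-thiazol-2-yl group of compound 2 on the shared core.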